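The compounds below may be only part of what the source reports. "The series", "measured", "known", "first", "only" and "open" are said of these compounds alone.

Measured so far: compound 1 `CCOC(=O)C1=C(C)N/C(=C/c2cc(C)n(-c3ccc(Br)cc3)c2C)C1=O` with 3.4; compound 2 `CCOC(=O)C1=C(C)N/C(=C/c2cc(C)n(-c3ccc([S+](C)[O-])cc3)c2C)C1=O` with "not determined" (no result reported).

In a physicochemical assay for lipophilicity, read by HPLC, at pH 7.4 (a higher number here means a more lipophilic compound, a lower number a more polar compound), compound 1 gives 3.4. For compound 2 no number exists in this assay, its result being "not determined" (no result reported), so compound 2 stands nowhere on this scale. Compound 3 `CCOC(=O)C1=C(C)N/C(=C/c2cc(C)n(-c3ccncc3)c2C)C1=O` differs from compound 2 by a group of 6 heavy atoms (5 carbon, 1 nitrogen; one six-membered aromatic ring with 1 hetero atom) in place of a group of 9 heavy atoms (7 carbon, 1 oxygen, 1 sulfur; one six-membered aromatic ring of carbon only), on an aromatic nitrogen. For the measured compounds named here, no measured pair shows this change, so the size of the step in this assay is not known from the data; a shift beyond the usual scatter, towards the polar end, is expected. Compound 3 is expected to give 1.9 in this assay, between 1.2 and 2.6.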

Compound 3, distribution coefficient: 3.2
Compound 3: middle estimate off by 1.30 log units, on the low side, and the stated range ends below it.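

At this position, on the aromatic nitrogen of the five-membered ring, putting pyridin-4-yl in place of 4-bromophenyl gives in this assay a number 0.20 log units lower from compound 1 to compound 3 (within the scatter), so this one pair does not separate the two groups on this scale. For the compounds shown here, this is the first readable step at this position, and nothing given here bears on why the two groups read alike.

The step between compound 2 and compound 3 cannot be read. On these data alone, what a ring carrying an amine or a carboxylic acid would give at this position remains open.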